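The source may hold more compounds than are shown below. What is called first, only, known or untested is meant among the compounds shown, and "the series" means these compounds.

Measured so far in an in vitro functional assay on HEK285-7 cells for antagonist activity at prostaglandin D2 receptor 2 (Homo sapiens), read by BRET and beta-arrestin recruitment; a higher number here means a weaker inhibitor, a lower number a stronger inhibitor:
- compound 1, `O=C(O)Cc1sc(C(c2ccc(F)cc2)c2ccc(F)cc2)nc1-c1ccc(Cl)cc1`: 180 nM
- compound 2, `N#Cc1cc(-c2nc(C(c3ccc(F)cc3)c3ccc(F)cc3)sc2CC(=O)O)ccc1F`: 520 nM
- compound 3, `NS(=O)(=O)c1ccc(-c2nc(C(c3ccc(F)cc3)c3ccc(F)cc3)sc2CC(=O)O)cc1`: a limit only, > 100000 nM

Compound 3 is the weakest of the three beyond doubt. For compound 3 the assay gives only a limit, > 100000 nM, and no number. The two steps that lead to it are both large: an at least 550-fold higher number from compound 1 to compound 3 (2.74 log units; beyond the scatter) and an at least 190-fold higher number from compound 2 to compound 3 (2.28 log units; beyond the scatter). Both end at the same point, (the limit of > 100000 nM in this assay, at which 1 of the 3 values shown sits).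

Compound 4, `NS(=O)(=O)c1cccc(-c2nc(C(c3ccc(F)cc3)c3ccc(F)cc3)sc2CC(=O)O)c1`, keeps every atom of compound 3 and only rearranges them: 3-sulfamoylphenyl in place of 4-sulfamoylphenyl on an aromatic carbon. Among the measured compounds shown here, no measured pair shows what moving the sulfamoyl group around the ring does; the only steps involving this group are the two large losses just named, and they concern putting it on rather than shifting it. Since compound 3 sits at the limit, a loss from there cannot be seen, and a recovery would have to be very large to bring compound 4 back toward compound 1 or compound 2. The step of a number no higher from compound 3 to compound 4 (the limit leaves the size open) is therefore expected to be small or unmeasurable. Compound 4 is estimated at 100000 nM in this assay, in a range from 10000 nM to 300000 nM, with a real chance that only a limit is reported again.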

Compound 4, half-maximal inhibitory concentration: 710 nM
Estimate against measurement, compound 4: 140-fold (2.15 log units) above; the whole stated range lies above it.
By their numbers in this assay, from the lowest: compound 1; then compounds 2 and 4 (each within the scatter of the next). At a limit, above all of these: compound 3.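

In this assay, the same atoms joined differently give an at least 140-fold lower number from compound 3 to compound 4 (2.14 log units; beyond the scatter), so the large losses seen earlier belong to 4-sulfamoylphenyl and not to the sulfamoyl group as such. At this place on the ring, next to the ring nitrogen, 3-sulfamoylphenyl cannot be told apart from 3-cyano-4-fluorophenyl, with a 1.4-fold higher number from compound 2 to compound 4 (0.14 log units; within the scatter), while 4-chlorophenyl still gives the stronger inhibitor, with a 3.9-fold higher number from compound 1 to compound 4 (0.60 log units; beyond the scatter). Compound 3 gives only a limit, so the step from it has a minimum size and no exact one: the limit of > 100000 nM in this assay, at which 1 of the 4 values shown sits.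

The compounds shown leave open whether this recovery needs the sulfamoyl group itself, or whether a phenyl ring carrying a methylsulfonyl or a carboxamide group in place of 3-sulfamoylphenyl would do the same. Going by these compounds, it is also open whether the ring position matters for other groups, for instance whether 3-chlorophenyl in place of 4-chlorophenyl would shift the number at all.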